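Boc-Protected Amino Acid Esters on a Quinolone Core

The compounds below may be only part of what the source reports. "The series", "measured", "known", "first", "only" and "open" are said of these compounds alone.

Compound 1 `C#CCn1cc(C(=O)NCCCOC(=O)[C@H](C)NC(=O)OC(C)(C)C)c(=O)c2ccc(Cl)nc21` — > 10000 nM
Compound 2 `C#CCn1cc(C(=O)N[C@@H](C)CCOC(=O)[C@H]2CCCN2C(=O)OC(C)(C)C)c(=O)c2ccc(Cl)nc21` — 3300 nM

For the measured compounds named here, the two compounds measured so far share a core and differ in the ester-bearing side chain attached to the amide. In a functional assay on SW-620 cells (Homo sapiens) for cytotoxicity, read by MTT assay, with a stated time of 72 h (on this read-out lower numbers stand for stronger inhibition and higher numbers for weaker inhibition), compound 2 gives 3300 nM. For compound 1 the read-out is a limit of the assay rather than a number, > 10000 nM. Going by the values given here, compound 2 therefore holds the only real number among the values shown, while the other value is the limit of > 10000 nM in this assay, at which 1 of the 2 values shown sits.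

Compound 3 `C#CCn1cc(C(=O)N[C@@H](C)CCOC(=O)[C@H](C)NC(=O)OC(C)(C)C)c(=O)c2ccc(Cl)nc21` has not been measured. It differs from compound 2 in one place: 1-((tert-butoxycarbonyl)amino)ethyl in place of 1-(tert-butoxycarbonyl)pyrrolidin-2-yl on a carbonyl carbon. Compound 1 carries the same 1-((tert-butoxycarbonyl)amino)ethyl ester and gave only a limit, so the change points, if anywhere, towards weaker inhibition. For compound 3 the estimate is 6000 nM, with an expected range of 2000 nM to 15000 nM, which would mean an expected step of a 1.8-fold higher number from compound 2 to compound 3 (0.26 log units; within the scatter) in the direction of weaker inhibition, possibly ending at the assay limit.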

Compound 3, half-maximal inhibitory concentration: > 10000 nM
Compound 3 gave a limit, no number; the forecaster's own chance of this, stated with the estimate: 40%; at least 1.6-fold (0.22 log units) between middle value and limit.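

Replacing 1-(tert-butoxycarbonyl)pyrrolidin-2-yl with 1-((tert-butoxycarbonyl)amino)ethyl on a carbonyl carbon gives, in this assay, an at least 3.0-fold higher number from compound 2 to compound 3 (0.48 log units; beyond the scatter). For the compounds shown here, this is the first step whose size can be stated, and it lies beyond the usual scatter, so the read-out is sensitive to this change in the ester group. In this pair, only the group containing the five-membered ring gives a real number, while the open-chain group joins the other compound at the assay limit: the limit of > 10000 nM in this assay, at which 2 of the 3 values shown sit.

The step from compound 1 to compound 3, which adds a methyl, cannot be read, as both values are limits. Also open, on these data alone, is how the read-out would respond to a free amine in place of the tert-butoxycarbonyl-protected nitrogen, or to a longer chain on the ester.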